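This account rests on a few compounds, and the source may have more. Where it says the series, first, only, none or still open, it means among the compounds named here.

Measured in an ADME assay on Huh7.5.1 cells (Homo sapiens) for cytotoxicity, read by ATP content, with a stated time of 48 h; a lower number here means that less compound is tolerated, a higher number that more compound is tolerated:
compound 1 `Cc1ccccc1-c1nc(CN2CCC(C(=O)NCCCN3CC(C)(C)CC(C)(C)C3)CC2)c(C)o1`: 4380 nM
compound 2 `Cc1oc(-c2ccc(F)cc2)nc1CN1CCC(C(=O)NCCCN2C[C@H](C)C[C@H](C)C2)CC1`: 12800 nM
compound 3 `Cc1oc(-c2ccc(Cl)c(Cl)c2)nc1CN1CCC(C(=O)NCCCN2C[C@H](C)C[C@H](C)C2)CC1`: 3170 nM

Compound 1 stands second highest of the three numbers in this assay; compound 3 lies within the scatter of compound 1, while compound 2 gives a higher number than compound 1, beyond the scatter. Within the data shown here, compound 4 `Cc1ccccc1-c1nc(CN2CCC(C(=O)NCCCN3CC4CCCC(C4)C3)CC2)c(C)o1` differs from compound 1 on a saturated chain carbon, three bonds along the chain from an amide-type nitrogen: a group of 9 heavy atoms (8 carbon, 1 nitrogen; one six-membered non-aromatic ring of carbon only, one six-membered non-aromatic ring with 1 hetero atom) in place of a group of 10 heavy atoms (9 carbon, 1 nitrogen; one six-membered non-aromatic ring with 1 hetero atom), on a saturated chain carbon, three bonds along the chain from an amide-type nitrogen The one measured step, a 4.0-fold lower number from compound 2 to compound 3 (0.61 log units; beyond the scatter), concerns a change on an aromatic carbon of the shared core and so does not bear on this exchange of ring groups on the saturated chain carbon. Among the measured compounds shown here, no measured step informs the change, so no step beyond the scatter is expected, a 1.0-fold higher number from compound 1 to compound 4 (0.00 log units; within the scatter). Compound 4 is accordingly estimated at 4400 nM, within 2000 nM to 9500 nM.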

Compound 4, half-maximal cytotoxic concentration: 10900 nM
For compound 4 the middle estimate is 2.5-fold (0.39 log units) below the measured one; the whole stated range lies below it.
By their numbers in this assay, from the lowest: compounds 3 and 1 (each within the scatter of the next); then compounds 4 and 2 (each within the scatter of the next).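

This position, on a saturated chain carbon, three bonds along the chain from an amide-type nitrogen, is not silent in this assay, where the exchange of ring groups gives a 2.5-fold higher number from compound 1 to compound 4 (0.40 log units; beyond the scatter) on the core of compound 1. The group of 9 heavy atoms, with its second six-membered ring, is thus tolerated better than the group of 10 heavy atoms, on this single pair. Nothing available explains the step.

From the compounds shown here alone, whether the step carries over to the 4-fluorophenyl and 3,4-dichlorophenyl compounds remains open. So does the standing of a morpholine at this position.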